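Lengthening the linker and swapping the halide

The compounds below may be only part of what the source reports. "The series", "measured", "known", "first", "only" and "open" are said of these compounds alone.

Two compounds with the shared core of compound 1 `COc1ccc(S(=O)(=O)NCCCNc2nccc(-c3c(-c4cccc(F)c4)nc4sccn34)n2)cc1` have been tested in a functional assay on A-375 cells (Homo sapiens) for cytotoxicity, read by MTT assay; on this read-out lower numbers stand for stronger inhibition and higher numbers for weaker inhibition. Compound 1 gives 5510 nM. Compound 2 `O=C(NCCNc1nccc(-c2c(-c3cccc(F)c3)nc3sccn23)n1)c1ccc(Cl)cc1` gives 2570 nM in this assay, the lower of the two numbers, with compound 1 standing a step beyond the scatter above it. Compound 3 `O=C(NCCCNc1nccc(-c2c(-c3cccc(F)c3)nc3sccn23)n1)c1ccc(F)cc1` has not yet been measured. It differs from compound 2 by (((4-fluorophenyl)carbonyl)amino)methyl in place of ((4-chlorophenyl)carbonyl)amino on a saturated chain carbon, two bonds along the chain from a nitrogen on an aromatic ring. For the measured compounds named here, no step between two measured compounds isolates either part of this change, so the direction must be judged from the two numbers alone. Compound 1 carries the longer three-carbon chain and gives 5510 nM, the weaker result, which suggests a modest loss. Compound 3 is therefore expected to land near 3600 nM, between 1500 nM and 9000 nM. This estimate means a step of a 1.4-fold higher number from compound 2 to compound 3 (0.15 log units; within the scatter), a small weakening that may not exceed the usual scatter.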

Compound 3, half-maximal inhibitory concentration: 14900 nM
Compound 3: the middle estimate sits 4.1-fold (0.62 log units) below what was measured; measured number above the stated range.
By their numbers in this assay, from the lowest: compound 2; then compound 1; then compound 3.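

In this assay, for the compounds shown here, the step of a 5.8-fold higher number from compound 2 to compound 3 (0.76 log units; beyond the scatter) shows that (((4-fluorophenyl)carbonyl)amino)methyl in place of ((4-chlorophenyl)carbonyl)amino at this chain carbon costs far more than the earlier compounds suggested. The step of a 2.7-fold higher number from compound 1 to compound 3 (0.43 log units; beyond the scatter), with (4-fluorophenyl)carbonyl in place of (4-methoxyphenyl)sulfonyl on an amine nitrogen, shows that the group on that nitrogen also matters on the longer chain, with the sulfonyl compound giving the lower number. Nothing measured here accounts for either step.

Going by these compounds, the step from compound 2 to compound 3 joins the lengthening of the chain with the exchange of chlorine for fluorine, so the share of each stays open. Also open, on these data alone, is how a still longer chain, or bromine on the phenyl ring, would read in this assay.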